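A few compounds are considered here, and "the series" means these few. Any claim that something is new, unique, unknown or untested is made for them only; others in the source may bear on it.

Measured so far in a functional assay on P388 cells (Mus musculus) for cytotoxicity; a lower number here means a stronger inhibitor, a higher number a weaker inhibitor:
compound 1, `COc1ccc(Cc2cn(C3CC3)c3c(F)c(-c4cc(C)nc(C)c4)c(F)cc3c2=O)cc1`, gives 21000 nM
compound 2, `Cc1cc(-c2c(F)cc3c(=O)c(Cc4ccccc4O)cn(C4CC4)c3c2F)cc(C)n1`, gives 670 nM
compound 3, `Cc1cc(-c2c(F)cc3c(=O)c(Cc4ccccc4)cn(C4CC4)c3c2F)cc(C)n1`, gives 7300 nM

Compound 1 stands with the highest number of the three. Compound 3 is nearest to it, a 2.9-fold lower number from compound 1 to compound 3 (0.46 log units; beyond the scatter), and compound 2 is furthest, a 31-fold lower number from compound 1 to compound 2 (1.50 log units; beyond the scatter). Between the two others, an 11-fold higher number from compound 2 to compound 3 (1.04 log units; beyond the scatter).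

Compound 4, `Cc1cc(-c2c(F)cc3c(=O)c(Cc4ccccc4N)cn(C4CC4)c3c2F)cc(C)n1`, is not yet measured. It differs from compound 1 in one place: 2-aminophenyl in place of 4-methoxyphenyl on a saturated chain carbon bound to an aromatic carbon. Among the compounds with values here, two measured steps bear on this. Removing the methoxy alone, as in compound 3, gives only a modest gain, a 2.9-fold lower number from compound 1 to compound 3 (0.46 log units; beyond the scatter). Putting a group with one hydrogen-bond donor at the same place, as in compound 2, gives a large gain, a 31-fold lower number from compound 1 to compound 2 (1.50 log units; beyond the scatter), and the part of that gain tied to the hydroxy group itself is seen in an 11-fold higher number from compound 2 to compound 3 (1.04 log units; beyond the scatter). Within the data shown here, no measured compound carries an amino group at this place, so the hydroxy result is the closest guide. The entering 2-aminophenyl also carries one hydrogen-bond donor and one acceptor, so a large fall in this assay is expected for compound 4, though with a wider range than for the measured pair.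

For compound 4 the expected value is 1500 nM, with a range of 400 nM to 6000 nM, meaning an expected step of a 14-fold lower number from compound 1 to compound 4 (1.15 log units; beyond the scatter).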

Compound 4, half-maximal inhibitory concentration: 2100 nM
Beside the measured number, compound 4's estimate is 1.4-fold (0.15 log units) below it; measured number inside the range.
By their numbers in this assay, from the lowest: compound 2; then compound 4; then compound 3; then compound 1.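

In this assay amino in place of hydrogen on an aromatic carbon gives a 3.5-fold lower number from compound 3 to compound 4 (0.54 log units; beyond the scatter), so the gain at this place is not confined to the hydroxy group of compound 2. The two groups are still not interchangeable, as amino in place of hydroxy gives a 3.1-fold higher number from compound 2 to compound 4 (0.50 log units; beyond the scatter) and the whole change from 4-methoxyphenyl to 2-aminophenyl gives a 10-fold lower number from compound 1 to compound 4 (1.00 log units; beyond the scatter), which places the amino compound in the middle of the series, with compound 2 still lowest. Nothing available accounts for the gap between the hydroxy and amino groups or for the gain over hydrogen.

Open, from the compounds shown here alone, is whether these gains depend on the hydrogen carried by the hydroxy and amino groups, a question that a methoxy or a dimethylamino group at the place of the hydroxy in compound 2 would address. Also open, going by these compounds, is how far the trend extends to other groups at that place, such as a carboxylic acid or a longer chain bearing an amine, and whether it holds beyond this single cell assay.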